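From 4-methoxyphenyl to 3-fluorophenyl in a cytotoxicity test

The source may hold more compounds than are shown below. What is called first, only, known or untested is meant among the compounds shown, and "the series" means these compounds.

Compound 1 `Clc1ccccc1/C=C/c1nnc(-c2ccc3c(c2)OCCO3)o1`: 368000 nM
Compound 2 `COc1ccc(/C=C/c2nnc(-c3ccc4c(c3)OCCO4)o2)cc1`: 312000 nM

Among the measured compounds shown here, in an ADME assay on HUVEC cells (Homo sapiens) for cytotoxicity, read by MTT assay, with a stated time of 24 h (a higher number here means that more compound is tolerated, a lower number that less compound is tolerated), compound 2 cannot be told apart from compound 1, the only other compound measured, since their values lie within the ordinary spread of repeated measurements. Compound 3 `Fc1cccc(/C=C/c2nnc(-c3ccc4c(c3)OCCO4)o2)c1` has not yet been measured. It carries 3-fluorophenyl in place of 4-methoxyphenyl on a double-bonded chain carbon bound to a double-bonded chain carbon. For the measured compounds named here, the one measured step that bears on this change altered the group at the same place, and it was small: a 1.2-fold lower number from compound 1 to compound 2 (0.07 log units; within the scatter). Going by the values given here, no measured compound carries 3-fluorophenyl, so this single step is only a weak guide. The expected step is a 1.1-fold higher number from compound 2 to compound 3 (0.04 log units; within the scatter), which means no change beyond the scatter in this assay. For compound 3 the estimated value is 340000 nM, with an expected range of 170000 nM to 620000 nM.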

Compound 3, half-maximal cytotoxic concentration: 295000 nM
Estimate against measurement, compound 3: 1.2-fold (0.06 log units) above, within the range that was stated.
By their numbers in this assay, from the lowest: compounds 3, 2 and 1 (each within the scatter of the next).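

Placing 3-fluorophenyl on a double-bonded chain carbon bound to a double-bonded chain carbon adds a third group to the comparison in this assay, both in place of 4-methoxyphenyl (a 1.1-fold lower number from compound 2 to compound 3 (0.02 log units; within the scatter)) and in place of 2-chlorophenyl (a 1.2-fold lower number from compound 1 to compound 3 (0.10 log units; within the scatter)). Compound 1, compound 2 and compound 3 therefore cannot be told apart, even though the step from compound 2 to compound 3 trades a group with one hydrogen-bond acceptor for one with none. No measurement is available to explain this lack of separation.

Still open is whether any group at this place can shift the number beyond the scatter, since all three groups shown are substituted phenyl rings. A phenyl ring carrying an amine or a carboxylic acid, or a longer carbon chain in place of the ring, could answer that.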